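A few compounds are considered here, and "the series" means these few. Any claim that something is new, unique, unknown or untested is made for them only; others in the source may bear on it.

In a functional assay on MDA-MB-231 cells (Homo sapiens) for inhibition, read by sulforhodamine B assay, with a stated time of 72 h (on this read-out lower numbers stand for stronger inhibition of growth and higher numbers for weaker inhibition of growth), compound 1 (`CN1CCN(C(=O)/C=C/c2ccncc2-c2ccc3ccccc3c2)CC1`) gives > 10000 nM as a limit of the assay and not a number. Compound 2 (`COC1CN(C(=O)/C=C/c2ccncc2-c2ccc3ccccc3c2)C1`) gives > 10000 nM and this too is only a limit. The evidence so far amounts to the limit of > 10000 nM in this assay, at which 2 of the 2 values shown sit, and nothing firmer. Going by the values given here, the one measured step is a step that the two limits leave unreadable from compound 1 to compound 2 and it offers no size to carry forward. Compound 3 (`O=C(/C=C/c1ccncc1-c1ccc2ccccc2c1)N1CCOCC1`) is reached from compound 2 by morpholin-4-yl in place of 3-methoxyazetidin-1-yl on a carbonyl carbon and carries morpholin-4-yl in place of 3-methoxyazetidin-1-yl on a carbonyl carbon. Because of the limit of > 10000 nM in this assay, at which 2 of the 2 values shown sit, no step beyond the usual scatter is expected in this assay and no direction can be argued. The estimated step that the limit leaves unreadable from compound 2 to compound 3 is accordingly small. Compound 3 is expected at 15000 nM within an estimated range of 6000 nM to 40000 nM and will most likely be reported as a limit again.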

Compound 3, concentration for 50% growth inhibition: 8980 nM
Compound 3: the middle estimate sits 1.7-fold (0.22 log units) above what was measured, within the range that was stated.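

Going by these compounds alone, with morpholin-4-yl on the carbonyl carbon, compound 3 gives 8980 nM in this assay, the first value in this set that is a number and not a limit. This makes two steps readable, an at least 1.1-fold lower number from compound 2 to compound 3 (0.04 log units; that floor lies within the scatter) and an at least 1.1-fold lower number from compound 1 to compound 3 (0.04 log units; that floor lies within the scatter), but each is only a floor that lies within the scatter, so neither shows that the change brings a real gain in growth inhibition. The true size of both steps remains tied to the limit that compound 1 and compound 2 share: the limit of > 10000 nM in this assay, at which 2 of the 3 values shown sit.

On these data alone, how far compound 1 and compound 2 actually lie from compound 3 remains open. So does whether another group on the carbonyl carbon, such as piperidin-1-yl or an open-chain dimethylamino group, would give a number well inside the range of this assay.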